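This account rests on a few compounds, and the source may have more. Where it says the series, first, only, none or still open, it means among the compounds named here.

Compound 3 (`CCOC(=O)C(=O)CC(=O)/C=C/c1cn(Cc2ccc(C#N)cc2)c2ccccc12`) has no number of its own: in a functional assay on MOLT-4 cells (Homo sapiens) for inhibition, read by MTT assay, with a stated time of 48 h (a higher number here means a weaker inhibitor, a lower number a stronger inhibitor), compound 3 has the entry "not determined" (no result reported) for its half-maximal inhibitory concentration. Compound 1 (`C/C=C/n1cc(/C=C/C(=O)CC(=O)C(=O)OCC)c2ccccc21`) gives no more help, since in this assay compound 1 also shows "not determined" (no result reported) as its entry. Only compound 2 (`CCOC(=O)C(=O)CC(=O)/C=C/c1cn(Cc2ccccc2)c2ccccc12`) has a reading, and compound 2 stands at > 40000 nM in this assay, which is a limit and not a number. The measured evidence therefore amounts to the limit of > 40000 nM in this assay, at which 1 of the 3 values shown sits, and nothing finer.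

Compound 4 (`N#Cc1ccc(Cn2cc(/C=C/C(=O)CC(=O)C(=O)O)c3ccccc32)cc1`) is still waiting for its measurement. The structural change is hydrogen in place of ethyl on an oxygen next to a carbonyl group and can also be read as ethoxycarbonyl to carboxy. Going by the values given here, with no measured step to give it a size, no shift beyond the usual scatter is expected from this change in this assay in either direction. Among the compounds with values here, this expectation rests on compound 2, whose limit of > 40000 nM is the only reading available. The assay may well report only a limit again. For compound 4 the expected value is 30000 nM with an estimated range from 8000 nM to 60000 nM in this read-out.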

Compound 4, half-maximal inhibitory concentration: > 40000 nM
Compound 4 was reported as a limit (the forecaster's own chance of this, stated with the estimate: 60%); at least 1.3-fold (0.12 log units) between middle value and limit.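

No step can be read between compound 3 and compound 4, as compound 3 has no number of its own in this assay. Compound 4 gives > 40000 nM, which is a limit and not a number. The compounds shown leave open whether ethoxycarbonyl to carboxy shifts the reading at all, and the evidence stops at one point: the limit of > 40000 nM in this assay, at which 2 of the 4 values shown sit.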